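A few compounds are considered here, and "the series" means these few. Any claim that something is new, unique, unknown or untested is made for them only; others in the source may bear on it.

Measured in a functional assay on the whole organism for inhibition, with Rattus norvegicus as the target, read by paw edema, with stated times of 1 h and 3 h; on this read-out lower numbers stand for an effect already at smaller amounts and higher numbers for an effect only at larger amounts of compound:
- compound 1 `COC(=O)CO/N=C(\C)c1ccc(Cl)cc1`: 24 mg/kg
- compound 2 `C/C(=N\OCCC(=O)O)c1ccc(Cl)cc1`: 80 mg/kg

Compound 2 stands as the higher of the two numbers, at 80 mg/kg. Compound 3 `C/C(=N\OC(C)C(=O)O)c1ccc(Cl)cc1` has the same atoms as compound 2, joined differently: 1-carboxyethyl in place of 2-carboxyethyl on an oxygen. The change is 1-carboxyethyl in place of 2-carboxyethyl on an oxygen. Among the measured compounds shown here, the only measured step, a 3.3-fold higher number from compound 1 to compound 2 (0.52 log units; beyond the scatter), is a different swap and bears on this change only loosely, as a modest step. No shift beyond the scatter is therefore expected in this assay, and no direction is favoured with confidence. The expected step is a 1.2-fold lower number from compound 2 to compound 3 (0.09 log units; within the scatter). Compound 3 is estimated at 65 mg/kg, with an expected range of 25 mg/kg to 170 mg/kg.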

Compound 3, dose for half-maximal effect: 55 mg/kg
Estimate against measurement, compound 3: 1.2-fold (0.07 log units) above, and the stated range covers the measured number.
By their numbers in this assay, from the lowest: compound 1; then compounds 3 and 2 (each within the scatter of the next).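

In this assay, 1-carboxyethyl in place of 2-carboxyethyl on an oxygen gives a 1.5-fold lower number from compound 2 to compound 3 (0.16 log units; within the scatter), so this rearrangement of the same atoms brings no shift that can be told from the scatter. The step from (methoxycarbonyl)methyl remains beyond the scatter with the new chain, at a 2.3-fold higher number from compound 1 to compound 3 (0.36 log units; beyond the scatter). No available measurement explains these numbers. Still open, as far as these compounds go, is whether 1-(methoxycarbonyl)ethyl on this oxygen would match compound 1, and how an amide or a longer chain would read in this assay.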